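Pyridinylmethyl in place of benzyl on the thienyl ether

The source may report more compounds than this note shows. Statements on the series, on what has been measured and on what is new or still open speak of the compounds shown alone.

Compound 2 `c1ccc(CN2CCC(CCOC(c3ccccc3)c3cccs3)CC2)cc1` holds the lowest of the two numbers recorded so far: in an assay on cell membranes for binding affinity to sodium-dependent dopamine transporter (Rattus norvegicus) (on this read-out lower numbers stand for stronger inhibition and higher numbers for weaker inhibition), compound 2 gives 27.2 nM. Compound 1 `c1ccc(C(OCCC2CCN(Cc3cccnc3)CC2)c2ccccc2)cc1` stands nearest; in this assay compound 1 gives 48.6 nM, a number within the scatter of that of compound 2, so no order between the two can be read. Compound 3 `c1ccc(C(OCCC2CCN(Cc3cccnc3)CC2)c2cccs2)cc1` has not been measured. It differs from compound 2 by pyridin-3-yl in place of phenyl on a saturated chain carbon bound to an amine nitrogen in a ring. For the measured compounds named here, no step between measured compounds covers this change on its own; compound 1 and compound 2 differ at two places, and their numbers sit within the scatter, so nothing at hand points to a step beyond the scatter in either direction. For compound 3 in this assay the estimate is 40 nM, with a range from 15 nM to 120 nM. The estimated step of a 1.5-fold higher number from compound 2 to compound 3 (0.17 log units; within the scatter) is expected to stay within the scatter.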

Compound 3, half-maximal inhibitory concentration: 58.3 nM
Compound 3: middle estimate off by 1.5-fold (0.16 log units), on the low side; measured number inside the range.
By their numbers in this assay, from the lowest: compounds 2, 1 and 3 (each within the scatter of the next, the first and the last beyond it).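

With thiophen-2-yl held constant, the change from phenyl to pyridin-3-yl on a saturated chain carbon bound to an amine nitrogen in a ring can now be read on its own in this assay: it gives a 2.1-fold higher number from compound 2 to compound 3 (0.33 log units; beyond the scatter), a modest loss that only just clears the scatter. With the (pyridin-3-yl)methyl group held constant, thiophen-2-yl in place of phenyl gives a 1.2-fold higher number from compound 1 to compound 3 (0.08 log units; within the scatter), so that exchange shows no readable effect on this background. Nothing at hand accounts for the size of the benzyl to (pyridin-3-yl)methyl step.

Still open, going by these compounds, is whether this step depends on where the ring nitrogen sits, as pyridin-2-yl or pyridin-4-yl would show. Also open, on these data alone, is whether a substituted benzyl such as 4-fluorobenzyl at the same place would stay within the scatter of compound 2 or move beyond it.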